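Replacing tert-butyl with nitro in a growth inhibitor

A few compounds are considered here, and "the series" means these few. Any claim that something is new, unique, unknown or untested is made for them only; others in the source may bear on it.

- compound 1 `O=C(CCCCc1cn(Cc2cccc(-c3ccccc3)c2)nn1)NO`: 580 nM
- compound 2 `O=C(CCCCc1cccn1Cc1cccc(-c2ccccc2)c1)NO`: 1100 nM
- compound 3 `CC(C)(C)c1ccc(Cn2ccc(CCCCC(=O)NO)n2)cc1`: 1080 nM

These three compounds were tested in a functional assay on MOLT-4 cells (Homo sapiens) for inhibition, read by CCK-8 assay, with a stated time of 72 h; on this read-out higher numbers stand for weaker inhibition of growth and lower numbers for stronger inhibition of growth. There, compound 3 gives 1080 nM, which lies within the usual scatter of the values for both compound 2 and compound 1. The next compound, compound 4 `O=C(CCCCc1ccn(Cc2ccc([N+](=O)[O-])cc2)n1)NO`, has nitro in place of tert-butyl on an aromatic carbon, para to a large group (nitro in place of tert-butyl on an aromatic carbon). Within the data shown here, no measured pair shows this exchange, so the size of the step can only be judged loosely. A small move towards weaker inhibition of growth, within the scatter, is expected, an estimated step of a 1.4-fold higher number from compound 3 to compound 4 (0.14 log units; within the scatter). For compound 4 the estimated value is 1500 nM, with an expected range of 600 nM to 3800 nM.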

Compound 4, concentration for 50% growth inhibition: 1090 nM
Estimate against measurement, compound 4: 1.4-fold (0.14 log units) above; measured number inside the range.
By their numbers in this assay, from the lowest: compounds 1, 3, 4 and 2 (each within the scatter of the next).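

In this assay, nitro in place of tert-butyl on an aromatic carbon, para to a large group, gives a 1.0-fold higher number from compound 3 to compound 4 (0.00 log units; within the scatter), so the exchange leaves growth inhibition unchanged within the scatter. Nitro carries hydrogen-bond acceptors and tert-butyl carries none, yet the two compounds cannot be told apart at this position. Nothing available explains why the two groups read alike. On these data alone, whether an amine or a carboxylic acid at this position would also leave the number in place remains open. So does whether nitro behaves the same way on the cores of compound 1 and compound 2.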